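Moving the furan attachment on the chloro compound

The compounds below may be only part of what the source reports. "The series", "measured", "known", "first", "only" and "open" are said of these compounds alone.

In a functional assay on HeLa S3 cells (Homo sapiens) for cytotoxicity, read by XTT assay, with a stated time of 3 days (on this read-out lower numbers stand for stronger inhibition and higher numbers for weaker inhibition), compound 3 `OC[C@H]1O[C@@H](n2cc(Cl)c3c(-c4ccco4)ncnc32)[C@H](O)[C@@H]1O` gives > 40000 nM, which is a limit of the assay and not a number. Its fluoro counterpart, compound 1 `OC[C@H]1O[C@@H](n2cc(F)c3c(-c4ccco4)ncnc32)[C@H](O)[C@@H]1O`, gives 8000 nM, and compound 2 `OC[C@H]1O[C@@H](n2cc(F)c3c(-c4ccoc4)ncnc32)[C@H](O)[C@@H]1O` gives 170 nM. Compound 4 `OC[C@H]1O[C@@H](n2cc(Cl)c3c(-c4ccoc4)ncnc32)[C@H](O)[C@@H]1O` differs from compound 3 as follows: furan-3-yl in place of furan-2-yl on an aromatic carbon. The same furan swap in the fluoro pair gave a 47-fold lower number from compound 1 to compound 2 (1.67 log units; beyond the scatter), while chloro in place of fluoro gave an at least 5.0-fold higher number from compound 1 to compound 3 (0.69 log units; beyond the scatter). A similarly large fall in the number is therefore expected in this assay, meaning stronger inhibition, although this rests on a single pair. The expected change is an at least 26-fold lower number from compound 3 to compound 4 (1.42 log units; beyond the scatter). Compound 4 is estimated at 1500 nM, with an expected range of 300 nM to 12000 nM.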

Compound 4, half-maximal inhibitory concentration: 2700 nM
Compound 4: the middle estimate sits 1.8-fold (0.26 log units) below what was measured; the range from low to high includes it.
By their numbers in this assay, from the lowest: compound 2; then compound 4; then compound 1. At a limit, above all of these: compound 3.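

In this assay, furan-3-yl in place of furan-2-yl lowers the number on the chloro compounds as well, with an at least 14-fold lower number from compound 3 to compound 4 (1.17 log units; beyond the scatter), so the swap acts in the same direction on both cores shown: the same change on two cores in this assay, a 47-fold lower number (1.67 log units; beyond the scatter) from compound 1 to compound 2 and an at least 14-fold lower number (1.17 log units; beyond the scatter) from compound 3 to compound 4; the limit leaves it open whether they differ. Chloro in place of fluoro now also raises the number with furan-3-yl in place, with a 16-fold higher number from compound 2 to compound 4 (1.20 log units; beyond the scatter): the same change on two cores in this assay, an at least 5.0-fold higher number (0.69 log units; beyond the scatter) from compound 1 to compound 3 and a 16-fold higher number (1.20 log units; beyond the scatter) from compound 2 to compound 4; the limit leaves it open whether they differ.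

On these data alone, whether a phenyl or a thiophen-3-yl group on this carbon would match furan-3-yl remains open. So does how a bromo group in place of chloro or fluoro would compare.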